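The compounds below may be only part of what the source reports. "The series", "measured", "known", "first", "only" and "open" are said of these compounds alone.

In a functional assay on L1210 cells (Mus musculus) for inhibition (on this read-out lower numbers stand for stronger inhibition and higher numbers for weaker inhibition), compound 1 (`Cc1nc(O)c2cc(CNc3ccc(S(=O)(=O)c4ccccc4)cc3)ccc2n1`) gives 14700 nM and compound 2 (`CCN(Cc1ccc2nc(C)nc(O)c2c1)c1ccc(S(=O)(=O)c2ccccc2)cc1`) gives 660 nM as the lower of the two numbers. Ethyl in place of hydrogen on a nitrogen on an aromatic ring accounts for a 22-fold lower number from compound 1 to compound 2 (1.35 log units; beyond the scatter) as a large step, and it is the only step measured. Compound 3 (`CCN(Cc1ccc2nc(C)nc(O)c2c1)c1ccc(C(=O)C(F)(F)F)cc1`) keeps the ethyl and carries (trifluoromethyl)carbonyl in place of phenylsulfonyl on an aromatic carbon. Among the compounds with values here, no measured step covers a change at that place, so the large step on the nitrogen sets no size for this one and shows only how far the two numbers lie apart. Starting from compound 2 at 660 nM a moderately higher number is expected in this assay with wide uncertainty. The expected change is a 3.8-fold higher number from compound 2 to compound 3 (0.58 log units; beyond the scatter) on this estimate. For compound 3 the estimated value is 2500 nM with an expected range from 500 nM to 12000 nM in all.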

Compound 3, half-maximal inhibitory concentration: 3400 nM
The estimate for compound 3 lay 1.4-fold (0.13 log units) below the measured number, within the range that was stated.
By their numbers in this assay, from the lowest: compound 2; then compound 3; then compound 1.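

In this assay, the group on the aromatic carbon proves to matter: a 5.2-fold higher number from compound 2 to compound 3 (0.71 log units; beyond the scatter), a modest step beyond the scatter, and smaller than the step on the nitrogen, a 22-fold lower number from compound 1 to compound 2 (1.35 log units; beyond the scatter). The phenylsulfonyl group and its ring of carbon can thus give way to (trifluoromethyl)carbonyl, a group with no ring and fewer heavy atoms, at a modest cost in this read-out, with the ethyl kept on the nitrogen. No measurement at hand explains why the number rises at this position.

Which part of phenylsulfonyl goes with the lower number stays open, as does whether this step would keep its size with hydrogen on the nitrogen in place of ethyl. Methylsulfonyl, which keeps the sulfonyl without the ring, and benzoyl, which keeps the ring on a carbonyl, would separate the two parts.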